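Compound 3 and the limit set by compound 2

The source may report more compounds than this note shows. Statements on the series, on what has been measured and on what is new or still open speak of the compounds shown alone.

Compound 1 `CN1CCCN(S(=O)(=O)c2ccc(-c3ccc4ncnc(Nc5ccc(OCc6cccc(F)c6)c(Cl)c5)c4c3)cc2)CC1` gives 1810 nM as a number.
Compound 2 `O=S(=O)(c1ccc(-c2ccc3ncnc(Nc4ccc(O)c(Cl)c4)c3c2)cc1)N1CCOCC1` gives > 15000 nM as a limit.

Both compounds were tested in an ADME assay on HepG2 cells (Homo sapiens) for cytotoxicity, read by MTT assay, with a stated time of 48 h (on this read-out lower numbers stand for stronger inhibition and higher numbers for weaker inhibition), and only compound 1 has a measured number there. Compound 2 sits at the limit of > 15000 nM in this assay, at which 1 of the 2 values shown sits, and so has a limit rather than a number. Compound 3 `O=S(=O)(c1ccc(-c2ccc3ncnc(Nc4ccc(OCc5cccc(Br)c5)c(Cl)c4)c3c2)cc1)N1CCOCC1` follows from compound 2 through one change, (3-bromobenzyl in place of hydrogen on an oxygen on an aromatic ring), which puts 3-bromobenzyl in place of hydrogen on an oxygen on an aromatic ring. Going by the values given here, no measured step shows what such a change does. Among the compounds with values here, a drop toward stronger inhibition in this assay is still expected, resting on compound 1 at 1810 nM as the one number available. The expected step, an at least 2.5-fold lower number from compound 2 to compound 3 (0.39 log units; beyond the scatter), is moderate in size and uncertain, and compound 3 may yet report only a limit. For compound 3 the estimated value is 6000 nM, with an expected range from 2000 nM to 15000 nM.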

Compound 3, half-maximal inhibitory concentration: > 15000 nM
Compound 3 gave a limit, no number; the forecaster's own chance of this, stated with the estimate: 35%; middle value at least 2.5-fold (0.39 log units) from the limit.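

In this assay, going by these compounds alone, compound 3 reports only a limit, > 15000 nM, and compound 2 also stands at a limit, so no step between the two can be read: the limit of > 15000 nM in this assay, at which 2 of the 3 values shown sit.

The compounds shown leave open what 3-bromobenzyl in place of hydrogen on an oxygen on an aromatic ring does in this assay.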